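Replacing the Nitrooxyethyl Arm on a Shared Pyrazoline Amide

A few compounds are considered here, and "the series" means these few. Any claim that something is new, unique, unknown or untested is made for them only; others in the source may bear on it.

Measured compounds:
- compound 1, `COc1ccc(C2CC(c3ccc(OC)c(OC)c3)=NN2C(=O)C(C)Br)c(OC)c1`, gives 69%
- compound 2, `COc1ccc(C2CC(c3ccc(OC)c(OC)c3)=NN2C(=O)C(C)O[N+](=O)[O-])c(OC)c1`, gives 56%

The read-out is a functional assay on the whole organism (strain albino) for inhibition, with Rattus norvegicus as the target, read by paw edema, with stated times of 30 min and 3 h, at a dose of 100 mg/kg by the oral route; on this read-out higher numbers stand for more inhibition at the one dose given (going by the name of the read-out) and lower numbers for less inhibition. Among the two numbers shown, compound 2 stands lowest, and its nearest neighbour is compound 1, whose value lies higher by a step that is beyond the scatter: a number 13 percentage points lower from compound 1 to compound 2 (beyond the scatter). Among the compounds with values here, that is the only step in the set, and it concerns nitrooxy in place of bromo on a saturated chain carbon bound to a carbonyl carbon and a saturated chain carbon.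

Compound 3, `COc1ccc(C2CC(c3ccc(OC)c(OC)c3)=NN2C(=O)CNc2ccc(/C(C)=N/O)cc2)c(OC)c1`, has not been measured. It differs from compound 2 in this way: a group of 12 heavy atoms (9 carbon, 2 nitrogen, 1 oxygen; one six-membered aromatic ring of carbon only) in place of a group of 6 heavy atoms (2 carbon, 1 nitrogen, 3 oxygen; no ring), on a carbonyl carbon. Within the data shown here, no measured step touches a change of this kind, so the one known step bears on it only as a sign that changes at the carbonyl carbon can move the number by a modest amount. For compound 3 the expected step is therefore small and of uncertain direction, a number 4 percentage points higher from compound 2 to compound 3 (within the scatter), and the estimate is 60%, with a range from 40% to 78%.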

Compound 3, a percentage reported as inhibition, in the whole organism at one dose (the size of the read-out at that dose, not a potency): 46%
Compound 3: middle estimate off by 14 percentage points, on the high side; the range from low to high includes it.
By their numbers in this assay, from the lowest: compounds 3 and 2 (each within the scatter of the next); then compound 1.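

In this assay, a far larger group on the carbonyl carbon, one carrying a six-membered aromatic ring of carbon only, cannot be told apart from the 1-(nitrooxy)ethyl arm, since the step of a number 10 percentage points lower from compound 2 to compound 3 (within the scatter) stays inside the usual spread of such measurements. The comparison with the bromo-bearing arm is clearer: a number 23 percentage points lower from compound 1 to compound 3 (beyond the scatter), which joins a number 13 percentage points lower from compound 1 to compound 2 (beyond the scatter) to show that both replacements on this carbonyl carbon, despite their very different size and makeup, stand apart from compound 1 in the same direction. Nothing measured here accounts for either step.

From the compounds shown here alone, what remains open is how much of this belongs to the bromine itself, as a chloro or hydroxy group on the same saturated chain carbon, or a plain ethyl arm with no such group, would test that directly. Going by these compounds, it is also open which part of the larger arm of compound 3 carries its effect, for which a simple amine or a carboxylic acid on the chain would offer a first comparison, and whether these gaps hold at other doses.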